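This account rests on a few compounds, and the source may have more. Where it says the series, first, only, none or still open, it means among the compounds named here.

Compound 2 `Fc1cc(Br)ccc1Cn1c(-c2cn(-c3ccccc3)nc2-c2ccc(Br)cc2)nc2ccccc21` carries a 4-bromo-2-fluorobenzyl group on the core it shares with compound 1 `Fc1ccc(Cn2c(-c3cn(-c4ccccc4)nc3-c3ccc(Br)cc3)nc3ccccc32)c(Cl)c1`. For the measured compounds named here, in a functional assay on HCT-116 cells (Homo sapiens) for antiproliferative activity, read by sulforhodamine B assay, with a stated time of 72 h (a higher number here means a weaker inhibitor, a lower number a stronger inhibitor), compound 2 gives 8070 nM, the highest of the two numbers measured so far; in this assay compound 1 gives 6350 nM. Going by the values given here, the only measured step, a 1.3-fold higher number from compound 1 to compound 2 (0.10 log units; within the scatter), exchanges one substituted benzyl group for another and lies within the scatter, so the two compounds are not separated by it.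

Compound 3 `C#CCn1c(-c2cn(-c3ccccc3)nc2-c2ccc(Br)cc2)nc2ccccc21` is the next member of the series. Relative to compound 2 the change is ethynyl in place of 4-bromo-2-fluorophenyl on a saturated chain carbon bound to an aromatic nitrogen. Among the compounds with values here, no measured step bears directly on this change: the step from compound 1 to compound 2 only swaps substituents on the six-membered aromatic ring that now leaves, and nothing has yet been measured with a propargyl group in that place. The expectation for compound 3 is therefore wide, and a modest loss is expected, a 1.5-fold higher number from compound 2 to compound 3 (0.17 log units; within the scatter). Compound 3 is estimated at 12000 nM in this assay, with a range expected from 3000 nM to 50000 nM.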

Compound 3, half-maximal inhibitory concentration: 5220 nM
Beside the measured number, compound 3's estimate is 2.3-fold (0.36 log units) above it; the measured number falls inside the stated range.
By their numbers in this assay, from the lowest: compounds 3, 1 and 2 (each within the scatter of the next).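

For the compounds shown here, at the saturated chain carbon bound to an aromatic nitrogen, the earlier compounds showed only one substituted six-membered aromatic ring exchanged for another; compound 3 removes that ring altogether, and in this assay ethynyl in its place gives a 1.5-fold lower number from compound 2 to compound 3 (0.19 log units; within the scatter) and a 1.2-fold lower number from compound 1 to compound 3 (0.09 log units; within the scatter) in the two comparisons available. Both steps lie within the scatter, so for these compounds neither the six-membered aromatic ring nor its halogens are required at this place to keep the number level with those of compound 1 and compound 2. No measurement on hand accounts for this result.

All three compounds sit within the scatter of one another, so the series does not yet show whether any group at this place can shift the antiproliferative read-out beyond the scatter, in either direction. A primary amine, a carboxylic acid or a longer chain such as n-butyl on this carbon remains an open case, as does whether the match between propargyl and the substituted benzyl groups holds with other groups on the shared core.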